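Thioether-linked benzamides: exchange on the sulfur-bound aryl

The source may hold more compounds than are shown below. What is called first, only, known or untested is meant among the compounds shown, and "the series" means these compounds.

Compound 1 `CCc1ccc(SCc2ccc(/C=C/C(=O)Nc3ccccc3N)cc2)cc1` belongs to the series, but in a functional assay on HCT-116 cells (Homo sapiens) for antiproliferative activity, read by CCK-8 assay, with a stated time of 72 h (a higher number here means a weaker inhibitor, a lower number a stronger inhibitor), compound 1 gives "not determined" (no result reported). Compound 3 `CC(C)(C)c1ccc(SCc2ccc(/C=C/C(=O)Nc3ccccc3N)cc2)cc1` also belongs to the series, and in this assay compound 3 gives "not determined" (no result reported). Within the data shown here, compound 2 `Nc1ccccc1NC(=O)c1ccc(CSc2cccc(F)c2)cc1` is the one member with a number: in this assay compound 2 gives 2870 nM, which is therefore the only point of reference, with nothing alongside it to rank it against.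

Compound 4 `Cc1cc(C)cc(SCc2ccc(C(=O)Nc3ccccc3N)cc2)c1` is the next entry to be measured. Relative to compound 2 the change is confined to one place: 3,5-dimethylphenyl in place of 3-fluorophenyl on a sulfur. Both groups are uncharged and carry no donor or acceptor, so the edit is a swap of one substituted aromatic ring for another on the sulfur.

Among the measured compounds shown here, no step between two measured compounds exists here, so the direction and size of the effect can only be expected, not inferred. A step within the scatter, or at most a modest one, is expected from compound 2 to compound 4, a 1.4-fold lower number from compound 2 to compound 4 (0.16 log units; within the scatter). For compound 4 in this assay the estimate is 2000 nM, with a range from 700 nM to 6000 nM.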

Compound 4, half-maximal inhibitory concentration: 2490 nM
Compound 4: the middle estimate sits 1.2-fold (0.10 log units) below what was measured; the measured number falls inside the stated range.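

In this assay the sulfur-bound aryl now has its first readable step, a 1.2-fold lower number from compound 2 to compound 4 (0.06 log units; within the scatter), so 3,5-dimethylphenyl and 3-fluorophenyl on a sulfur are not separated by this read-out. This exchange takes out the fluorine and goes from 7 to 8 heavy atoms, with 0 hydrogen-bond donors and 0 hydrogen-bond acceptors on both sides, and the value stays within the scatter. No measurement at hand speaks to why the two groups read alike.

Steps involving compound 1 and compound 3 cannot be read, so the series still offers only this one comparison. On these data alone, whether an aryl on the sulfur carrying an amine or a carboxylic acid, or a longer chain in place of the aryl, would give a step beyond the scatter remains open.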